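Swapping fluoro for cyano on a benzophenone-like amide

The compounds below may be only part of what the source reports. "The series", "measured", "known", "first", "only" and "open" are said of these compounds alone.

Measured compounds:
- compound 1, `CC(O)(C(=O)Nc1ccc(S(=O)(=O)c2ccc(Br)cc2)cc1)C(F)(F)F`: > 30000 nM
- compound 2, `CC(O)(C(=O)Nc1ccc(C(=O)c2ccccc2)cc1F)C(F)(F)F`: 11000 nM

Compound 1 carries a sulfone link and a bromine on its far ring. In a functional assay (Cavia porcellus) with sulfonylurea receptors; K-ATP channels (Homo sapiens) as the target (a higher number here means a weaker inhibitor, a lower number a stronger inhibitor), compound 1 reaches only the limit of the assay, > 30000 nM, so no number is known for it. Compound 2 instead has a carbonyl link, a bare far ring and a fluorine on the ring that bears the amide. In this assay compound 2 gives 11000 nM. Among the measured compounds shown here, that is the only true number among the two values shown, so compound 2 stands as the one point of reference, with compound 1 sitting at the limit (the limit of > 30000 nM in this assay, at which 1 of the 2 values shown sits).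

Compound 3, `CC(O)(C(=O)Nc1ccc(C(=O)c2ccccc2)cc1C#N)C(F)(F)F`, is not yet measured. It differs from compound 2 in one place: cyano in place of fluoro on an aromatic carbon, ortho to a large group and meta to a benzoyl group. For the measured compounds named here, because no step between two measured compounds is known, there is no guide for the size of this exchange, and the step from compound 2 to compound 3 is expected to stay small, at a 1.2-fold lower number from compound 2 to compound 3 (0.09 log units; within the scatter), with either direction possible. Compound 3 is therefore estimated at 9000 nM, within a range from 2500 nM to 30000 nM.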

Compound 3, half-maximal inhibitory concentration: 3800 nM
Beside the measured number, compound 3's estimate is 2.4-fold (0.37 log units) above it; the measured number falls inside the stated range.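

Exchanging fluoro for cyano on this aromatic carbon, ortho to a large group and meta to a benzoyl group, gives a 2.9-fold lower number from compound 2 to compound 3 (0.46 log units; beyond the scatter) in this assay. The step is modest, but it shows that the group at this one place can shift the result while the rest of the molecule stays the same. This is the first pair of measured compounds that differ in one place, so the shared core now has a measured step instead of a lone point of reference, although nothing shown here accounts for the size or direction of that step.

As far as these compounds go, with a single exchange at a single place, it remains open whether a plain hydrogen, an amine, a carboxylic acid or a methoxy group on this carbon would lower the number further or raise it again. Compound 1 differs from compound 2 in more than one place, so it offers no step for this position, and its value is only a limit: the limit of > 30000 nM in this assay, at which 1 of the 3 values shown sits.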